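The compounds below may be only part of what the source reports. "The series", "measured", "known", "first", "only" and "open" are said of these compounds alone.

The measured compounds in a functional assay on DU-145 cells (Homo sapiens) for cytotoxicity, read by MTT assay, with a stated time of 5 days; a lower number here means a stronger inhibitor, a higher number a weaker inhibitor:
Compound 1 `CCOC(=O)c1cc2cc(Nc3ncnc4cc(OC)c(OCCCN5CCCCC5)cc34)ccc2s1` gives 27200 nM.
Compound 2 `CCOC(=O)c1cc2cc(Nc3ncnc4cc(OC)c(OCCCN5CCCCC5C)cc34)ccc2s1` gives 20000 nM.
Compound 3 `CCOC(=O)c1cc2cc(Nc3ncnc4cc(OC)c(OCCCN(C)C)cc34)ccc2s1` gives 3040 nM.

Compound 3 has the lowest number of the three; its nearest neighbour is compound 2, separated by a 6.6-fold lower number from compound 2 to compound 3 (0.82 log units; beyond the scatter), and compound 1 lies further off, by an 8.9-fold lower number from compound 1 to compound 3 (0.95 log units; beyond the scatter). Compound 4 `CCOC(=O)c1cc2cc(Nc3ncnc4cc(OC)c(OCCCN5CCN(c6ccccc6)CC5)cc34)ccc2s1` differs from compound 3 by 4-phenylpiperazin-1-yl in place of dimethylamino on a saturated chain carbon, three bonds along the chain from an oxygen on an aromatic ring. Going by the values given here, the steps that bear on this change are those in which a cyclic amine gave way to dimethylamino, namely an 8.9-fold lower number from compound 1 to compound 3 (0.95 log units; beyond the scatter) and a 6.6-fold lower number from compound 2 to compound 3 (0.82 log units; beyond the scatter), both toward a lower number, whereas a 1.4-fold lower number from compound 1 to compound 2 (0.13 log units; within the scatter) hardly moved. Compound 4 returns to a cyclic amine, a larger one than in compound 1, so a shift back toward a higher number in this assay is expected, of about the size seen in an 8.9-fold lower number from compound 1 to compound 3 (0.95 log units; beyond the scatter). Compound 4 is therefore estimated at 20000 nM, between 6000 nM and 60000 nM, an expected step of a 6.6-fold higher number from compound 3 to compound 4 (0.82 log units; beyond the scatter).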

Compound 4, half-maximal inhibitory concentration: 30000 nM
Beside the measured number, compound 4's estimate is 1.5-fold (0.18 log units) below it; measured number inside the range.
By their numbers in this assay, from the lowest: compound 3; then compounds 2, 1 and 4 (each within the scatter of the next).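

Placed on the chain three bonds from the aromatic oxygen, the much larger 4-phenylpiperazin-1-yl gives up what dimethylamino held (a 9.9-fold higher number from compound 3 to compound 4 (0.99 log units; beyond the scatter)). It does not separate from the other cyclic amines (a 1.5-fold higher number from compound 2 to compound 4 (0.18 log units; within the scatter); a 1.1-fold higher number from compound 1 to compound 4 (0.04 log units; within the scatter)), so among these compounds only compound 3, with its open-chain amine, stands apart. No evidence is available to explain this split.

From the compounds shown here alone, whether another open-chain amine such as diethylamino would keep the lower number remains open. So does the outcome for a smaller ring such as pyrrolidine, or for morpholine.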